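Extending the Ether Chain on Compound 3

The compounds below may be only part of what the source reports. "The series", "measured", "known", "first", "only" and "open" are said of these compounds alone.

Three members of one shared core have been measured for cytotoxicity. Compound 1 `CCOC(=O)c1c(-c2cc3ccccc3oc2=O)nn(-c2ccc(Br)cc2)c1C(=O)OCC` in a functional assay on HeLa cells (Homo sapiens) for cytotoxicity, read by MTT assay, with a stated time of 48 h (a higher number here means a weaker inhibitor, a lower number a stronger inhibitor), gives 250000 nM. Compound 2 `CCOC(=O)c1c(-c2cc3ccc(OC)cc3oc2=O)nn(-c2cccc(C)c2)c1C(=O)OCC` gives 35000 nM, and compound 3 `CCOC(=O)c1c(-c2cc3ccc(OC)cc3oc2=O)nn(-c2cccc(Cl)c2)c1C(=O)OCC` gives 205000 nM. Within the data shown here, the only step between measured compounds that differ in a single place is a 5.9-fold higher number from compound 2 to compound 3 (0.77 log units; beyond the scatter), which concerns the aryl group on the nitrogen. Compound 3 therefore stands second highest of the three numbers: compound 1 is its nearest neighbour, within the scatter, while compound 2 is furthest, beyond it.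

Compound 4 `CCOC(=O)c1c(-c2cc3ccc(OCC=C(C)C)cc3oc2=O)nn(-c2cccc(Cl)c2)c1C(=O)OCC` differs from compound 3 by 2-methylprop-1-en-1-yl in place of hydrogen on a saturated chain carbon bound to an oxygen on an aromatic ring. Among the measured compounds shown here, no measured step touches this position; the single step available, a 5.9-fold higher number from compound 2 to compound 3 (0.77 log units; beyond the scatter), concerns a different part of the molecule and so cannot guide the size or direction of the change here. With nothing to suggest a shift, the number for compound 4 is expected to stay close to that of compound 3, with a step not beyond the usual scatter, and the wide range reflects that lack of a precedent. Compound 4 is estimated at 150000 nM, with a range from 40000 nM to 500000 nM, which corresponds to an expected 1.4-fold lower number from compound 3 to compound 4 (0.14 log units; within the scatter).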

Compound 4, half-maximal inhibitory concentration: 110000 nM
For compound 4 the middle estimate is 1.4-fold (0.13 log units) above the measured one; measured number inside the range.
By their numbers in this assay, from the lowest: compound 2; then compounds 4, 3 and 1 (each within the scatter of the next, the first and the last beyond it).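

In this assay the exchange of methoxy for (3-methylbut-2-en-1-yl)oxy gives a 1.9-fold lower number from compound 3 to compound 4 (0.27 log units; within the scatter) and is the first step shown at this position. Among these compounds, the added 2-methylprop-1-en-1-yl, with its 4 heavy atoms and 1 double bond outside aromatic rings, therefore changes the number by no more than the scatter can account for, whereas the only earlier single-place step, chloro in place of methyl on the aryl group on the nitrogen, gives a 5.9-fold higher number from compound 2 to compound 3 (0.77 log units; beyond the scatter) and so marks that part of the molecule as the one where a difference has been seen so far. Nothing shown explains why the ether position gives so little response here.

On these data alone, it remains open whether a saturated 3-methylbutyl chain, a longer chain, or a chain ending in an amine or a carboxylic acid would also stay within the scatter of compound 3. Among the compounds shown here, it is equally open whether (3-methylbut-2-en-1-yl)oxy would give a similar step on the methyl-bearing aryl group of compound 2, the one compound here with a clearly lower number.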